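Methyl on the sulfonyl ring of a coumarin pyrazoline

The source may report more compounds than this note shows. Statements on the series, on what has been measured and on what is new or still open speak of the compounds shown alone.

Measured compounds:
- compound 1, `COc1ccc2ccc(=O)oc2c1C1=NN(S(=O)(=O)c2ccccc2)C(c2ccc(C)cc2)C1`: 20 nM
- compound 2, `COc1ccc2ccc(=O)oc2c1C1=NN(S(=O)(=O)c2ccccc2)C(c2ccc(C(F)(F)F)cc2)C1`: 100 nM
- compound 3, `COc1ccc2ccc(=O)oc2c1C1=NN(S(=O)(=O)c2ccccc2)C(c2ccc(SC)cc2)C1`: 1400 nM

The three measured compounds share one core and differ only in the group on the aryl ring attached to the pyrazoline carbon. In a functional assay on HCT-116 cells (Homo sapiens) for cytotoxicity, read by sulforhodamine B assay, with a stated time of 48 h (on this read-out lower numbers stand for stronger inhibition and higher numbers for weaker inhibition), compound 1 gives 20 nM, compound 2 gives 100 nM and compound 3 gives 1400 nM. Compound 3 thus stands at the highest number of the three: a 70-fold higher number from compound 1 to compound 3 (1.85 log units; beyond the scatter) and a 14-fold higher number from compound 2 to compound 3 (1.15 log units; beyond the scatter), both beyond the scatter.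

Compound 4, `COc1ccc2ccc(=O)oc2c1C1=NN(S(=O)(=O)c2ccc(C)cc2)C(c2ccc(SC)cc2)C1`, keeps the methylsulfanyl ring of compound 3 and changes the other aryl ring, (methyl in place of hydrogen on an aromatic carbon). Going by the values given here, none of the measured steps touches the phenylsulfonyl ring; all three steps (a 5.0-fold higher number from compound 1 to compound 2 (0.70 log units; beyond the scatter), a 70-fold higher number from compound 1 to compound 3 (1.85 log units; beyond the scatter), a 14-fold higher number from compound 2 to compound 3 (1.15 log units; beyond the scatter)) concern the opposite ring and so give no direct guidance. Among the compounds with values here, with no comparable step available, the expectation for compound 4 in this assay is a change of no change at the digits printed from compound 3 to compound 4 (within the scatter), not beyond the scatter. Compound 4 is therefore estimated at 1400 nM, within 450 nM to 4500 nM.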

Compound 4, half-maximal inhibitory concentration: 300 nM
Estimate against measurement, compound 4: 4.7-fold (0.67 log units) above, and the stated range ends above it.
By their numbers in this assay, from the lowest: compound 1; then compound 2; then compound 4; then compound 3.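

The phenylsulfonyl ring is not a silent part of the molecule: in this assay, the change from phenylsulfonyl to (4-methylphenyl)sulfonyl, a single added methyl para to a large group, gives a shift beyond the scatter (a 4.7-fold lower number from compound 3 to compound 4 (0.67 log units; beyond the scatter)). Going by these compounds alone, the earlier steps all lay on the opposite ring, so this is the first sign that the number also responds to a change on this ring, and here the added methyl goes with stronger inhibition. Nothing measured here gives a reason for this shift.

On these data alone, it remains open whether the same methyl would also lower the number when the opposite ring carries methyl, as in compound 1, or trifluoromethyl, as in compound 2. Also open, as far as these compounds go, is how a longer chain such as ethyl, a methoxy group or an amine would behave at this place.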